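Series notes: phenyl in place of aminopyrazinyl

This account rests on a few compounds, and the source may have more. Where it says the series, first, only, none or still open, it means among the compounds named here.

Compound 1 `Cc1nc2c3ccccc3ccc2c2nc3c(ccc4ccccc43)c(-c3nccnc3N)c12` carries a 3-aminopyrazin-2-yl group on the shared core; in a functional assay on AGS cells (Homo sapiens) for cytotoxicity, read by MTT assay, with a stated time of 48 h (a higher number here means a weaker inhibitor, a lower number a stronger inhibitor), compound 1 gives 2260 nM. Compound 2 `Cc1nc2c3ccccc3ccc2c2nc3c(ccc4ccccc43)c(-c3ccccc3Cl)c12`, with 2-chlorophenyl instead, gives 52500 nM, and compound 3 `Cc1nc2c3ccccc3ccc2c2nc3c(ccc4ccccc43)c(-c3ccccc3S)c12`, with 2-sulfanylphenyl, gives 4070 nM. Compound 1 thus holds the lowest of the three numbers: the gap to compound 3 is a 1.8-fold higher number from compound 1 to compound 3 (0.26 log units; within the scatter), the gap to compound 2 is a 23-fold higher number from compound 1 to compound 2 (1.37 log units; beyond the scatter), and between those two compounds the step is a 13-fold lower number from compound 2 to compound 3 (1.11 log units; beyond the scatter).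

Compound 4 `Cc1nc2c3ccccc3ccc2c2nc3c(ccc4ccccc43)c(-c3ccccc3)c12` is not yet measured. Its change from compound 1 is phenyl in place of 3-aminopyrazin-2-yl on an aromatic carbon. Among the compounds with values here, the two measured replacements of the 3-aminopyrazin-2-yl group gave a 23-fold higher number from compound 1 to compound 2 (1.37 log units; beyond the scatter) and a 1.8-fold higher number from compound 1 to compound 3 (0.26 log units; within the scatter), one beyond the scatter and one within it, so for compound 4 a move toward a higher number in this assay is expected, of a size somewhere between those two, since no measured step shows the bare phenyl itself. For compound 4 the estimate is 9000 nM, within 2500 nM to 35000 nM. The step this estimate implies is a 4.0-fold higher number from compound 1 to compound 4 (0.60 log units; beyond the scatter).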

Compound 4, half-maximal inhibitory concentration: > 80000 nM
Compound 4 ended at the assay's limit; the forecaster's own chance of this, stated with the estimate: 5%; middle value at least 8.8-fold (0.94 log units) away from the limit.
By their numbers in this assay, from the lowest: compounds 1 and 3 (each within the scatter of the next); then compound 2. At a limit, above all of these: compound 4.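

In this assay compound 4 gives > 80000 nM, which is a limit of the assay and not a number. The unsubstituted phenyl on this aromatic carbon, opposite the ring nitrogen, gives an at least 35-fold higher number from compound 1 to compound 4 (1.54 log units; beyond the scatter) and an at least 19-fold higher number from compound 3 to compound 4 (1.29 log units; beyond the scatter): a phenyl ring alone does not reproduce the numbers seen with 3-aminopyrazin-2-yl or 2-sulfanylphenyl, and adding sulfanyl to that ring is a large step. Chloro is not separated in the same way, with an at least 1.5-fold higher number from compound 2 to compound 4 (0.18 log units; that floor lies within the scatter), so a change from the limit on adding this group is not shown.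

Open, from the compounds shown here alone, is whether a 2-aminophenyl or 2-hydroxyphenyl group at this position would stay close to compound 3. Also open, going by these compounds, is whether a pyrazin-2-yl group without the amine would stay close to compound 1.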